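Changing One Sulfonyl Aryl Group on an Inactive Series

A few compounds are considered here, and "the series" means these few. Any claim that something is new, unique, unknown or untested is made for them only; others in the source may bear on it.

Compound 1 `O=S(=O)(Nc1ccc(-c2nc3cc(NS(=O)(=O)c4ccccc4)ccc3o2)cc1)c1ccccc1`: > 100000 nM, a limit of the assay rather than a number.
Compound 2 `COc1ccc(S(=O)(=O)Nc2ccc(-c3nc4cc(NS(=O)(=O)c5ccc(OC)cc5)ccc4o3)cc2)cc1`: > 100000 nM, again a limit of the assay.
Compound 3 `O=S(=O)(Nc1ccc(-c2nc3cc(NS(=O)(=O)c4ccc(Br)cc4)ccc3o2)cc1)c1ccc(Br)cc1`: > 100000 nM, also a limit of the assay.

All three compounds share the same core and carry two sulfonamide arms, and all three were tested in an assay on isolated protein for inhibition of thiosulfate sulfurtransferase (Homo sapiens); a higher number here means a weaker inhibitor, a lower number a stronger inhibitor. None gave a measurable number: each sits at the limit of > 100000 nM in this assay, at which 3 of the 3 values shown sit. Compound 2 therefore stands at the limit, and nothing in the results separates it from compound 1 or compound 3; no ordering among them can be read from these values.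

Compound 4 `COc1ccc(S(=O)(=O)Nc2ccc3oc(-c4ccc(NS(=O)(=O)c5cc(Br)ccc5OC)cc4)nc3c2)cc1` is a variation of compound 2 in which one sulfonyl aryl group is changed: 5-bromo-2-methoxyphenyl in place of 4-methoxyphenyl on a sulfonyl sulfur. Going by the values given here, since no pair of measured compounds differs in only one place, no measured step shows how such a change moves the result in this assay, and the direction has to be guessed. With every measured compound at the limit, the expectation for compound 4 is no step beyond the usual scatter, so it is estimated at 100000 nM, within a range of 30000 nM to 300000 nM. The expected step is a number no higher from compound 2 to compound 4 (the limit leaves the size open), most likely ending once more as a limit rather than a number.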

Compound 4, half-maximal inhibitory concentration: > 100000 nM
Compound 4: no number, only a limit; the forecaster's own chance of this, stated with the estimate: 80%; the middle value sits exactly at the limit.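

In this assay compound 4 gives > 100000 nM, which is a limit of the assay and not a number. Compound 2 also stands at a limit, and the step between compound 2 and compound 4 cannot be read. The compounds shown leave open whether any sulfonyl aryl group on the shared core can give a measurable value.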